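Shifting a Methoxy Group on a Pendant Phenyl Ring

The source may report more compounds than this note shows. Statements on the series, on what has been measured and on what is new or still open speak of the compounds shown alone.

Of the compounds shown here, two with a shared core have been measured. Compound 1 `CCCC1C(=O)N(C)c2cnc(Nc3ccc(S(N)(=O)=O)cc3)nc2N1C` carries a propyl group on a saturated ring carbon, and in an assay on Sf9 cells for inhibition of serine/threonine-protein kinase 4 (Homo sapiens), read by luminescence and ADP-Glo, with a stated time of 1 h, in the presence of a further agent that is not named here (on this read-out lower numbers stand for stronger inhibition and higher numbers for weaker inhibition), compound 1 gives 206 nM. Compound 2 `COc1cccc(C2C(=O)N(C)c3cnc(Nc4ccc(S(N)(=O)=O)cc4)nc3N2C)c1` carries a 3-methoxyphenyl group at that carbon instead, and in this assay compound 2 gives 954 nM. For the measured compounds named here, the step of a 4.6-fold higher number from compound 1 to compound 2 (0.67 log units; beyond the scatter) is the only measured step so far, and it leaves compound 2 as the higher of the two numbers.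

Compound 3 `COc1ccccc1C1C(=O)N(C)c2cnc(Nc3ccc(S(N)(=O)=O)cc3)nc2N1C` differs from compound 2 in one respect: 2-methoxyphenyl in place of 3-methoxyphenyl on a saturated ring carbon. Going by the values given here, no measured step bears on this change; the single known step, a 4.6-fold higher number from compound 1 to compound 2 (0.67 log units; beyond the scatter), exchanges a propyl chain for an aryl ring and says nothing about where the methoxy group sits on that ring. The value of compound 2 is therefore the only anchor, and no step beyond the scatter is expected in either direction. The step expected from compound 2 to compound 3 in this assay is a 1.1-fold lower number from compound 2 to compound 3 (0.03 log units; within the scatter). Compound 3 is accordingly estimated at 900 nM in this assay, with a range from 300 nM to 3000 nM.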

Compound 3, half-maximal inhibitory concentration: 251 nM
Compound 3: the middle estimate sits 3.6-fold (0.55 log units) above what was measured; the whole stated range lies above it.
By their numbers in this assay, from the lowest: compounds 1 and 3 (each within the scatter of the next); then compound 2.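

Where the methoxy group sits on the phenyl ring proves to matter at this saturated ring carbon: this assay gives a 3.8-fold lower number from compound 2 to compound 3 (0.58 log units; beyond the scatter) as the result of that move alone, although the group that leaves and the group that enters have the same atoms. The earlier step from propyl to 3-methoxyphenyl had suggested a cost for an aryl ring at this carbon, but that reading does not hold for every aryl ring, since the change to 2-methoxyphenyl gives a 1.2-fold higher number from compound 1 to compound 3 (0.09 log units; within the scatter) and so cannot be told apart from the propyl group on this read-out. The material shown offers nothing that would explain why the two methoxyphenyl groups differ.

Going by these compounds, it remains open whether an unsubstituted phenyl group, an ethoxy group in place of the methoxy group, or a chain longer than propyl at this carbon would fall with compound 2 or with compound 3 in this assay as well. On these data alone, it also remains open whether the difference between the two methoxyphenyl groups would persist if the sulfonamide on the shared core were replaced by a carboxylic acid or an amine.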